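The compounds below may be only part of what the source reports. "The series", "measured", "known", "first", "only" and "open" are said of these compounds alone.

The measured compounds are compound 1 `CC(COc1ccccc1-c1ccccc1)N1CCC(NS(=O)(=O)c2cccc(Cl)c2)CC1`, which gives 32 nM in an assay on HEK293 cells for displacement of a labelled ligand from 5-hydroxytryptamine receptor 7 (Homo sapiens), read by scintillation counting, with a stated time of 1 h; a lower number here means a stronger inhibitor, a higher number a weaker inhibitor; compound 2 `CC(COc1ccccc1-c1ccccc1)N1CCC(NS(=O)(=O)c2ccc(F)cc2)CC1`, which gives 34 nM; and compound 3 `O=S(=O)(NC1CCN(CC(O)COc2ccccc2-c2ccccc2)CC1)c1cccc(Cl)c1`, which gives 33 nM. Compound 4 `O=S(=O)(NC1CCN(CC(O)COc2ccccc2-c2ccccc2)CC1)c1ccc(F)cc1` has not yet been measured.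

The difference between the core of compound 1 and the core of compound 3 is not broken down here. Compound 1 and compound 2 differ in one place: 4-fluorophenyl in place of 3-chlorophenyl on a sulfonyl sulfur. That change made a 1.1-fold higher number from compound 1 to compound 2 (0.03 log units; within the scatter). The same change, (4-fluorophenyl in place of 3-chlorophenyl on a sulfonyl sulfur), leads from compound 3 to compound 4, and the surroundings of the place are the same in both pairs. Because the earlier pair showed a 1.1-fold higher number from compound 1 to compound 2 (0.03 log units; within the scatter), a step of about the same size is expected here. The step is estimated at a 1.1-fold higher number from compound 3 to compound 4 (0.03 log units; within the scatter). Compound 4 is therefore expected to give 35 nM in this assay, with a likely range of 18 nM to 70 nM.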

Compound 4, inhibition constant: 59 nM
Beside the measured number, compound 4's estimate is 1.7-fold (0.23 log units) below it; measured number inside the range.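

In this assay the change from 3-chlorophenyl to 4-fluorophenyl on a sulfonyl sulfur gives a 1.8-fold higher number from compound 3 to compound 4 (0.25 log units; within the scatter) and compares with the step on the other core as follows: the same change on two cores in this assay, a 1.1-fold higher number (0.03 log units; within the scatter) from compound 1 to compound 2 and a 1.8-fold higher number (0.25 log units; within the scatter) from compound 3 to compound 4, 1.7-fold (0.23 log units) apart, within the scatter of two such steps. On these two cores, then, the change carries over with no difference that the measurements can separate, and on neither core does the change itself stand out from the scatter. This does not show that the change has a real effect on either core, nor that the same would hold on any further core.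

The compounds shown leave open how a nitrile, a methyl group or a carboxylic acid on that aromatic ring would read. They also leave open what an amine or a longer chain in place of the aromatic ring on the sulfonyl sulfur would do.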